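From Selenium to Sulfur on a Shared Core

The compounds below may be only part of what the source reports. "The series", "measured", "known", "first", "only" and "open" are said of these compounds alone.

Compound 2 `C[Se]/C(=N\C(=O)c1cccs1)NC(=O)c1cccs1` has been measured in a functional assay on K562 cells (Homo sapiens) for cytotoxicity, read by MTT assay, with a stated time of 72 h (a higher number here means a weaker inhibitor of growth, a lower number a stronger inhibitor of growth), where compound 2 gives 6070 nM. Its only companion so far is compound 1 `C[Se]/C(=N\C(=O)c1ccco1)NC(=O)c1ccco1`, which in this assay gives 8780 nM; the two numbers lie within the usual scatter of each other, so neither stands apart from the other. Compound 3 `CS/C(=N\C(=O)c1cccs1)NC(=O)c1cccs1` has not yet been measured. Compound 3 differs from compound 2 by a group of 2 heavy atoms (1 carbon, 1 sulfur; no ring) in place of a group of 2 heavy atoms (1 carbon, 1 selenium; no ring), on a carbon with a double bond to nitrogen. Among the compounds with values here, no measured pair here shows this exchange, so its size is unknown from these data. The step from compound 2 to compound 3 is expected to be modest, toward a higher number, about a 2.0-fold higher number from compound 2 to compound 3 (0.30 log units; within the scatter). The estimated value for compound 3 is 12000 nM, expected to fall between 4000 nM and 40000 nM.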

Compound 3, concentration for 50% growth inhibition: 72600 nM
Compound 3: middle estimate off by 6.1-fold (0.78 log units), on the low side; measured number above the stated range.
By their numbers in this assay, from the lowest: compounds 2 and 1 (each within the scatter of the next); then compound 3.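

In this assay the exchange of the selenium-bearing group for methylsulfanyl gives a 12-fold higher number from compound 2 to compound 3 (1.08 log units; beyond the scatter) and so counts as a large step. Compounds 1 and 2 both carry the selenium-bearing group on the carbon with a double bond to nitrogen, so they could not show how much the number at this position depends on that group. Here the two groups both count 2 heavy atoms, and the exchange of selenium for sulfur alone separates compound 2 from compound 3, though nothing given here explains the size of the step.

On these data alone, whether the same exchange on the core of compound 1 gives a step of similar size remains open. Also open, as far as these compounds go, is how the number would move with an ethylsulfanyl chain or an amine on this carbon.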